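This account rests on a few compounds, and the source may have more. Where it says the series, first, only, none or still open, it means among the compounds named here.

Measured so far:
- compound 1 `O=C(CC(c1ccc(Cl)cc1)C(C(=O)Nc1ccccn1)C(=O)Nc1ccccn1)c1ccccc1`: 13600 nM
- compound 2 `O=C(CC(c1cccs1)C(C(=O)Nc1ccccn1)C(=O)Nc1ccccn1)c1ccccc1`: "not active" (no number reported)
- compound 3 `O=C(CC(c1ccc([N+](=O)[O-])cc1)C(C(=O)Nc1ccccn1)C(=O)Nc1ccccn1)c1ccccc1`: 30000 nM

Going by the values given here, in a functional assay on HeLa cells (Homo sapiens) for inhibition, read by MTT assay, with a stated time of 48 h (on this read-out lower numbers stand for stronger inhibition and higher numbers for weaker inhibition), compound 3 at 30000 nM has the higher of the only two numbers, while compound 2 offers no number for comparison. The unmeasured compound 4 `O=C(CC(c1ccc(Cl)cc1Cl)C(C(=O)Nc1ccccn1)C(=O)Nc1ccccn1)c1ccccc1` differs from compound 3 as follows: 2,4-dichlorophenyl in place of 4-nitrophenyl on a saturated chain carbon bound to two saturated chain carbons. Put simply, it has 2,4-dichlorophenyl in place of 4-nitrophenyl on a saturated chain carbon bound to two saturated chain carbons.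

Among the compounds with values here, one measured step bears on this change: a 2.2-fold higher number from compound 1 to compound 3 (0.34 log units; beyond the scatter). It is a modest step, with nitro in place of chloro on an aromatic carbon. Compound 4 carries chloro where compound 3 carries nitro, so reading that step backwards points to a lower number. Within the data shown here, the additional chloro has no measured step of its own, which keeps the uncertainty wide.

A modest step toward a lower number is therefore expected: a 2.3-fold lower number from compound 3 to compound 4 (0.36 log units; beyond the scatter). The estimated value for compound 4 is 13000 nM, with an expected range from 5000 nM to 30000 nM.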

Compound 4, half-maximal inhibitory concentration: 13500 nM
Compound 4: middle estimate off by 1.0-fold (0.02 log units), on the low side; low and high end bracket the measured number.
By their numbers in this assay, from the lowest: compounds 4 and 1 (each within the scatter of the next); then compound 3.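

In this assay, the second chloro on the aromatic ring can now be read on its own: adding it in place of hydrogen gives a 1.0-fold lower number from compound 1 to compound 4 (0.00 log units; within the scatter), so this addition brings no real change in the number. Exchanging 4-nitrophenyl for 2,4-dichlorophenyl on the saturated chain carbon gives a 2.2-fold lower number from compound 3 to compound 4 (0.35 log units; beyond the scatter), a modest step of about the same size as the earlier exchange of chloro for nitro, and so the nitro compound stays apart from both chloro compounds. Nothing measured here explains either step.

On these data alone, what an amine, a carboxylic acid or a methoxy group would do on this aromatic ring remains open. So does whether any group at this position can move the number much further than the chloro groups do.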